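From compound 3 to compound 4: a longer alkyl chain

The source may report more compounds than this note shows. Statements on the series, on what has been measured and on what is new or still open speak of the compounds shown alone.

Measured in a functional assay on HCT-116 cells (Homo sapiens) for antiproliferative activity, read by MTT assay, with a stated time of 72 h; a higher number here means a weaker inhibitor, a lower number a stronger inhibitor
- compound 1 `N=C(NC(=N)NC1CCCC1)Nc1ccc(C(F)(F)F)cc1` gives 3800 nM
- compound 2 `CC(C)CNC(=N)NC(=N)Nc1ccc(C(F)(F)F)cc1` gives 3500 nM
- compound 3 `CC(C)CNC(=N)NC(=N)Nc1ccc(F)c(F)c1` gives 29700 nM

Compound 3 has the highest number of the three, and its gaps to compound 1 and compound 2 both lie beyond the scatter. The next compound is compound 4 `CCCCCCCNC(=N)NC(=N)Nc1ccc(F)c(F)c1`, with hexyl in place of isopropyl on a saturated chain carbon bound to an amine nitrogen.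

For the measured compounds named here, only one measured step bears on this change: a 1.1-fold lower number from compound 1 to compound 2 (0.04 log units; within the scatter), which lies within the scatter. That step puts isobutyl in place of cyclopentyl and does not test a long chain, so it gives no direct measure of the size to expect. Going by the values given here, the series holds no measured compound with a hexyl group. A lower number in this assay is nevertheless expected, on thin evidence, since compound 3 at 29700 nM sits high in the series. The expected change is a 5.9-fold lower number from compound 3 to compound 4 (0.77 log units; beyond the scatter). The estimate for compound 4 is 5000 nM, with an expected range of 1500 nM to 15000 nM.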

Compound 4, half-maximal inhibitory concentration: 1800 nM
Compound 4: the middle estimate sits 2.8-fold (0.44 log units) above what was measured; measured number inside the range.
By their numbers in this assay, from the lowest: compounds 4, 2 and 1 (each within the scatter of the next, the first and the last beyond it); then compound 3.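

In this assay, the saturated chain carbon bound to an amine nitrogen proves to be a place where the read-out responds strongly: hexyl in place of isopropyl gives a 17-fold lower number from compound 3 to compound 4 (1.22 log units; beyond the scatter). For the compounds shown here, the only earlier step at this nitrogen, a 1.1-fold lower number from compound 1 to compound 2 (0.04 log units; within the scatter), exchanged cyclopentyl for isobutyl and stayed within the scatter, so it gave no sign that this substituent could matter so much. No measurement in hand accounts for the size of the new step.

A single pair cannot show whether the number keeps falling with chain length, so a butyl group or a longer chain such as octyl would be needed to define the trend. Going by these compounds, whether hexyl gives a step of similar size alongside the trifluoromethyl group of compound 2 also remains open.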